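This account rests on a few compounds, and the source may have more. Where it says the series, first, only, none or still open, it means among the compounds named here.

Measured compounds
Compound 1 `CC1=C(c2cccc(O)c2)C(c2ccc(OC[C@H](C)N3CC[C@@H](C)C3)cc2)Oc2cc(O)ccc21`: 50 ng.h/mL
Compound 2 `CC1=C(c2ccccc2)C(c2ccc(OC[C@H](C)N3CC[C@@H](C)C3)cc2)Oc2ccc(O)cc21`: 1000 ng.h/mL
Compound 3 `CC1=C(c2cccc(O)c2)C(c2ccc(OC[C@@H](C)N3CCCC3)cc2)Oc2ccc(O)cc21`: "not determined" (no result reported) (no result reported)

Notes. In an ADME assay on the whole organism for pharmacokinetics, with Mus musculus as the target, at a dose of 10 mg/kg by the oral route (a lower number here means less compound in the circulation, a higher number more compound in the circulation at the dose given), compound 2 gives 1000 ng.h/mL, the higher of the two numbers available for the series. Its nearest measured neighbour is compound 1, which in this assay gives 50 ng.h/mL, a markedly lower area under the concentration-time curve that lies beyond the usual scatter. Compound 3 carries no number in this assay and contributes nothing to the comparison. No pair of measured compounds differs in exactly one place, so no single step can be isolated from the data shown.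

Compound 4 `CC1=C(c2ccc(F)cc2)C(c2ccc(OC[C@H](C)N3CC[C@@H](C)C3)cc2)Oc2ccc(O)cc21` has not yet been run in this assay. It differs from compound 2 by one change:
fluoro in place of hydrogen on an aromatic carbon
The fluoro group enters on an aromatic carbon of a six-membered aromatic ring of carbon only, para to a large group. Within the data shown here, no measured pair reports this change, so there is no step to lean on. The expected step from compound 2 to compound 4, no change at the digits printed from compound 2 to compound 4 (within the scatter), is small and within the scatter in either direction. On that basis compound 4 is estimated at 1000 ng.h/mL in this assay, with a range from 300 ng.h/mL to 3000 ng.h/mL.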

Compound 4, area under the concentration-time curve: 2000 ng.h/mL
Compound 4: middle estimate off by 2.0-fold (0.30 log units), on the low side; measured number inside the range.
By their numbers in this assay, from the lowest: compound 1; then compounds 2 and 4 (each within the scatter of the next).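

Fluoro in place of hydrogen on this aromatic carbon, para to a large group, is the first change in the series that can be read on its own: in this assay it gives a 2.0-fold higher number from compound 2 to compound 4 (0.30 log units; within the scatter). The step is within the scatter, so the phenyl to 4-fluorophenyl change leaves the area under the curve of compound 2 in place, and the fluoro group is tolerated at this position in this assay without any gain that can be claimed for it. The data shown hold no measurement that bears on the size of this step.

Open, on these data alone, is whether a chloro, methoxy or trifluoromethyl group on the same carbon would also stay within the scatter of compound 2, or whether only a single fluorine atom is accommodated there. Among these compounds, also open is whether the same fluoro change would read the same way on a compound that carries a hydroxyl group on this ring, as compound 1 does, since compound 1 differs from compound 2 in more than one place and no single step connects them.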